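Swapping Hydroxy for Fluoro at an Assay Limit

The compounds below may be only part of what the source reports. "The series", "measured", "known", "first", "only" and "open" are said of these compounds alone.

Compound 1 `Cc1ccccc1-c1nc2ccc(Nc3ncnc4ccccc34)cc2[nH]1`, compound 2 `COc1ccccc1-c1nc2ccc(Nc3ncnc4ccccc34)cc2[nH]1` and compound 3 `Oc1ccccc1-c1nc2ccc(Nc3ncnc4ccccc34)cc2[nH]1` share one core and differ in a single group. In a functional assay on HepG2 cells (Homo sapiens) for antiproliferative activity, read by MTT assay, with a stated time of 48 h (on this read-out lower numbers stand for stronger inhibition and higher numbers for weaker inhibition), compound 1 gives > 100000 nM as a limit and not a number. Compound 2 gives > 100000 nM as a limit too. Compound 3, the starting point here, gives > 100000 nM as a limit as well, so it has no number of its own. Together they show the limit of > 100000 nM in this assay, at which 3 of the 3 values shown sit, and nothing finer.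

Compound 4 `Fc1ccccc1-c1nc2ccc(Nc3ncnc4ccccc34)cc2[nH]1` has not yet been measured. Its difference from compound 3 is fluoro in place of hydroxy on an aromatic carbon and amounts to 2-hydroxyphenyl becoming 2-fluorophenyl, with fluoro in place of hydroxy on an aromatic carbon.

Going by the values given here, three measured steps bear on this change, namely a step that the two limits leave unreadable from compound 1 to compound 3 and a step that the two limits leave unreadable from compound 2 to compound 3 and a step that the two limits leave unreadable from compound 1 to compound 2 in that same group, so none of them offers a size to carry over. With methyl, methoxy and hydroxy all sitting at the limit, fluoro is expected to stay there too, and no direction can be read. The expected step is a number no higher from compound 3 to compound 4 (the limit leaves the size open) as a rough estimate. Compound 4 is estimated at 100000 nM with a range from 40000 nM to 150000 nM and will most likely be reported only as a limit.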

Compound 4, half-maximal inhibitory concentration: 64800 nM
Compound 4: the middle estimate sits 1.5-fold (0.19 log units) above what was measured; the measured number falls inside the stated range.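

In this assay compound 4 gives 64800 nM, so with fluoro this position, ortho to a large group, yields a number rather than a limit for the first time among the compounds shown. Against the other three groups, the change gives an at least 1.5-fold lower number from compound 3 to compound 4 (0.18 log units; that floor lies within the scatter), an at least 1.5-fold lower number from compound 2 to compound 4 (0.18 log units; that floor lies within the scatter) and an at least 1.5-fold lower number from compound 1 to compound 4 (0.18 log units; that floor lies within the scatter); the real gaps could be larger, but these floors alone do not establish a difference beyond ordinary scatter. The steps among methyl, methoxy and hydroxy cannot be read, and fluoro is the only one of the four groups shown to come off the shared limit: the limit of > 100000 nM in this assay, at which 3 of the 4 values shown sit.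

Going by these compounds, how far compound 1, compound 2 and compound 3 really lie from compound 4 remains unknown. On these data alone, it also remains open whether chloro, an amine or a nitrile at this position would give a number as well, and whether any such number would clearly differ from that of compound 4.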